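Sulfonyl group change from compound 3 to compound 4

The source may hold more compounds than are shown below. What is called first, only, known or untested is meant among the compounds shown, and "the series" means these compounds.

In an ADME assay (liver) for metabolic stability, with Liver microsome (Homo sapiens) as the target, read by LC-MS, using microsomes and NADPH, with a stated time of 5 min, at 37 degrees C (on this read-out higher numbers stand for fast clearance and lower numbers for slow clearance), compound 3 `CCn1c([C@@H](C)NS(=O)(=O)c2c(F)cc(F)cc2F)nc2ccc(C(F)(F)F)cc21` gives 19 mL.min-1.g-1, the lower of the two actual numbers in the series. Compound 1 `CCn1c(C(C)NS(=O)(=O)c2ccc(Cl)cc2)nc2ccncc21` stands higher at 93 mL.min-1.g-1. Compound 2 `CCn1c([C@@H](C)NS(=O)(=O)C2CC2)nc2ccc(C(F)(F)F)cc21` returns only a limit, < 3 mL.min-1.g-1, and not a number.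

The next change is 1,2-dimethyl-1H-imidazol-4-yl in place of 2,4,6-trifluorophenyl on a sulfonyl sulfur, with 1,2-dimethyl-1H-imidazol-4-yl in place of 2,4,6-trifluorophenyl on a sulfonyl sulfur, which gives compound 4 `CCn1c([C@@H](C)NS(=O)(=O)c2cn(C)c(C)n2)nc2ccc(C(F)(F)F)cc21`. Going by the values given here, the only measured step at this place is an at least 6.3-fold higher number from compound 2 to compound 3 (0.80 log units; beyond the scatter), with 2,4,6-trifluorophenyl in place of cyclopropyl. That single step rests on compound 2 and compound 3, and it shows that the read-out in this assay can respond to the group on the sulfonyl sulfur. With 2,4,6-trifluorophenyl leaving, a fall of moderate size is expected, smaller than that step and only modestly beyond the scatter. The expected change is a 2.4-fold lower number from compound 3 to compound 4 (0.38 log units; beyond the scatter). For compound 4 the estimate is 8 mL.min-1.g-1, with an expected range from 3 mL.min-1.g-1 to 22 mL.min-1.g-1.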

Compound 4, intrinsic clearance in microsomes: 43 mL.min-1.g-1
Estimate against measurement, compound 4: 5.4-fold (0.73 log units) below; the whole stated range lies below it.
By their numbers in this assay, from the lowest: compound 3; then compound 4; then compound 1. At a limit, below all of these: compound 2.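

At the sulfonyl sulfur, 1,2-dimethyl-1H-imidazol-4-yl in place of 2,4,6-trifluorophenyl gives a 2.3-fold higher number from compound 3 to compound 4 (0.35 log units; beyond the scatter) in this assay, so the two aromatic groups are not interchangeable here, and the ring with 2 hetero atoms gives the higher number. Against cyclopropyl, the same group gives an at least 14-fold higher number from compound 2 to compound 4 (1.15 log units; beyond the scatter), so among these three groups on the sulfonyl sulfur, cyclopropyl gives the lowest reading and both aromatic groups stand above it. The cyclopropyl reading of compound 2 is a limit and not a number, which leaves the true size of that step open: the limit of < 3 mL.min-1.g-1 in this assay, at which 1 of the 4 values shown sits.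

Open, going by these compounds, is whether an ethyl chain or a piperidine ring on the sulfonyl sulfur would stay near cyclopropyl or move towards the aromatic groups. Also open, on these data alone, is how much of the step belongs to the two methyl groups and how much to the imidazole ring itself.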